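Branching the hydroxyalkyl ester side chain on the shared core

A few compounds are considered here, and "the series" means these few. Any claim that something is new, unique, unknown or untested is made for them only; others in the source may bear on it.

Compound 1 `CCCCC(O)CC(=O)O[C@H](CC=C(C)C)C1=CC(=O)c2c(O)ccc(O)c2C1=O` gives 45300 nM in a functional assay on DU-145 cells (Homo sapiens) for cytotoxicity, read by MTT assay (a higher number here means a weaker inhibitor, a lower number a stronger inhibitor), and stands highest of the two numbers shown, with compound 3 nearest. Compound 2 `CC(C)=CC[C@@H](OC(=O)c1ccoc1)C1=CC(=O)c2c(O)ccc(O)c2C1=O` reaches only the limit > 100000 nM in this assay. Compound 3 `CC(C)=CC[C@@H](OC(=O)C1CCCO1)C1=CC(=O)c2c(O)ccc(O)c2C1=O` gives 10500 nM. The measured steps exchange the whole ester substituent: an at least 2.2-fold higher number from compound 1 to compound 2 (0.34 log units; beyond the scatter); a 4.3-fold lower number from compound 1 to compound 3 (0.63 log units; beyond the scatter); an at least 9.5-fold lower number from compound 2 to compound 3 (0.97 log units; beyond the scatter). Compound 4 `CC(C)=CC[C@@H](OC(=O)CC(C)(O)C(C)C)C1=CC(=O)c2c(O)ccc(O)c2C1=O` differs from compound 1 by 1-hydroxy-1,2-dimethylpropyl in place of 1-hydroxypentyl on a saturated chain carbon bound to a carbonyl carbon. Among the measured compounds shown here, no measured step bears on this rearrangement of the same atoms within the chain; the ring exchanges are of another kind, so no shift beyond the scatter is expected, with the expected step being a 1.1-fold lower number from compound 1 to compound 4 (0.05 log units; within the scatter). Compound 4 is therefore estimated at 40000 nM, expected between 15000 nM and 110000 nM.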

Compound 4, half-maximal inhibitory concentration: 16900 nM
Beside the measured number, compound 4's estimate is 2.4-fold (0.37 log units) above it; the measured number falls inside the stated range.
By their numbers in this assay, from the lowest: compounds 3 and 4 (each within the scatter of the next); then compound 1. At a limit, above all of these: compound 2.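

In this assay, rearranging the same atoms on a saturated chain carbon bound to a carbonyl carbon is enough to move the number, giving a 2.7-fold lower number from compound 1 to compound 4 (0.43 log units; beyond the scatter); the shape of the chain therefore counts here, not only exchange of the whole substituent. The open-chain 2-hydroxy-2,3-dimethylbutyl group also matches the oxolan-2-yl ring, with a 1.6-fold higher number from compound 3 to compound 4 (0.21 log units; within the scatter), so no ring is required at this position. The step of an at least 5.9-fold lower number from compound 2 to compound 4 (0.77 log units; beyond the scatter) is only a bound, compound 2 standing at a limit: the limit of > 100000 nM in this assay, at which 1 of the 4 values shown sits.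

Which branch of the chain carries the step remains open. So does whether an amine or a carboxylic acid in place of the hydroxy group, or a longer branched chain, would hold the number.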